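Purine-benzamide series: 4-methylpiperazin-1-yl exchanged for (4-methylphenyl)amino

This account rests on a few compounds, and the source may have more. Where it says the series, first, only, none or still open, it means among the compounds named here.

Of the compounds shown here, three have been measured in a functional assay on HepG2 cells (Homo sapiens) for antiproliferative activity, read by CCK-8 assay, with a stated time of 72 h, tested at 2 uM; on this read-out lower numbers stand for a weaker effect and higher numbers for a stronger effect at the one concentration tested. Compound 1 `CN1CCN(c2nc(Cl)nc3c2ncn3Cc2ccc(C(=O)Nc3ccccc3N)cc2)CC1` gives 60.4%. Compound 2 `CC(C)n1cnc2c(Nc3cccc(Cl)c3)nc(NCOCc3ccc(C(=O)Nc4ccccc4N)cc3)nc21` gives 1.48%, and compound 3 `Nc1ccccc1NC(=O)c1ccc(CNc2nc(Cl)nc3c2ncn3Cc2ccccc2)cc1` gives 5.01%. Compound 1 therefore stands highest of the three numbers; its gap to compound 3 is the nearer one and lies beyond the scatter, and its gap to compound 2 is the wider one, also beyond the scatter. Among the compounds with values here, no two of the measured compounds differ in only one place, so no single-point step within the measured set is available.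

Compound 4 `Cc1ccc(Nc2nc(Cl)nc3c2ncn3Cc2ccc(C(=O)Nc3ccccc3N)cc2)cc1` has not yet been measured in this assay. Relative to compound 1 it carries (4-methylphenyl)amino in place of 4-methylpiperazin-1-yl on an aromatic carbon. The two weaker measured compounds, compound 2 and compound 3, both bear an amino-linked group on their core, but each differs from compound 1 in several places at once, so their low values cannot be turned into a step for this single change. On the balance of what is shown, the step from compound 1 to compound 4 is expected to be downward and beyond the scatter, a number 25.4 percentage points lower from compound 1 to compound 4 (beyond the scatter). Compound 4 is accordingly estimated at 35%, with a range from 8% to 65%.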

Compound 4, a percentage reported as inhibition, at one concentration (the size of the read-out at that concentration, not a potency): 76.2%
Beside the measured number, compound 4's estimate is 41.2 percentage points below it; measured number above the stated range.
By their numbers in this assay, from the lowest: compounds 2 and 3 (each within the scatter of the next); then compound 1; then compound 4.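

The exchange of 4-methylpiperazin-1-yl for (4-methylphenyl)amino gives a number 15.8 percentage points higher from compound 1 to compound 4 (beyond the scatter) in this assay and is a modest step, the first single-place comparison available in this series. It shows that this aromatic carbon, next to the ring nitrogen, keeps its effect at the one concentration tested when the six-membered non-aromatic ring is replaced by a six-membered aromatic ring of carbon only, attached through an amino nitrogen. The piperazine ring is therefore not needed here for the read-out, at least with the chloro group and the rest of the core of compound 1 in place, and nothing shown gives a measured reason for the step.

The compounds shown leave open whether the rise depends on the methyl group or on the aromatic ring itself, a question that plain phenylamino, cyclohexylamino or morpholine at this position would address. Within the data shown here, also open is whether the same exchange holds when another group, such as a methoxy group or a nitrile, stands in place of the chloro group, and a single-concentration read-out gives no potency for either compound.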